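Aryl Amide Swap on a Shared Core in U-251 Cells

The source may hold more compounds than are shown below. What is called first, only, known or untested is meant among the compounds shown, and "the series" means these compounds.

Compound 1 `O=C(Nc1ccc(Cl)c(-c2nnc3c(Cl)cccn23)c1)c1ccc(F)cc1Cl` in a functional assay on U-251 cells (Homo sapiens) for antiproliferative activity, read by MTT assay, with a stated time of 72 h (a lower number here means a stronger inhibitor, a higher number a weaker inhibitor), gives > 100000 nM, a limit of the assay.
Compound 2 `O=C(Nc1ccc(Cl)c(-c2nnc3c(Cl)cccn23)c1)c1ccccn1` in this assay gives 79000 nM.
Compound 3 `O=C(Nc1ccc(Cl)c(-c2nnc3c(Cl)cccn23)c1)c1ccc(C(F)(F)F)cc1F` in this assay gives > 100000 nM, again a limit.

Compound 1 therefore stands only at a limit, without a number of its own; the limit of > 100000 nM in this assay, at which 2 of the 3 values shown sit, is where two of the three results sit. Compound 4 `O=C(Nc1ccc(Cl)c(-c2nnc3c(Cl)cccn23)c1)c1cccc(Cl)c1` differs from compound 1 by 3-chlorophenyl in place of 2-chloro-4-fluorophenyl on a carbonyl carbon. Within the data shown here, the one measured step at the same carbonyl carbon, an at least 1.2-fold lower number from compound 1 to compound 2 (0.10 log units; that floor lies within the scatter), is too small to show a direction. One therefore expects no step beyond the scatter in this assay, and the expected step is a number no higher from compound 1 to compound 4 (the limit leaves the size open). Compound 4 is expected at 100000 nM, between 30000 nM and 300000 nM, most likely reported again as a limit.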

Compound 4, half-maximal inhibitory concentration: 43100 nM
Compound 4: middle estimate off by 2.3-fold (0.37 log units), on the high side; the measured number falls inside the stated range.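

In this assay the carbonyl carbon now carries a step beyond the scatter, namely an at least 2.3-fold lower number from compound 1 to compound 4 (0.36 log units; beyond the scatter) for 3-chlorophenyl in place of 2-chloro-4-fluorophenyl, so the aryl group at this place can move the number. Against pyridin-2-yl the same group gives only a 1.8-fold lower number from compound 2 to compound 4 (0.26 log units; within the scatter) and the two cannot be ordered. All but a floor of these results remains modest, and the steps to compound 3 cannot be read.

As far as these compounds go, the full size of the first step stays open: the limit of > 100000 nM in this assay, at which 2 of the 4 values shown sit. From the compounds shown here alone, whether an amine or a carboxylic acid on this aryl ring would bring the number lower is also open.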